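Dihydropyridine diesters: trimming propyl to methyl on one side

The compounds below may be only part of what the source reports. "The series", "measured", "known", "first", "only" and "open" are said of these compounds alone.

Measured so far:
Compound 1, `CCCOC(=O)C1=C(C)NC(C)=C(C(=O)OCCC)C1c1[nH]cnc1Cl`, 63.1 nM
Compound 2, `CC1=C(C(=O)OC(C)(C)C)C(c2[nH]cnc2Cl)C(C(=O)OC(C)(C)C)=C(C)N1`, 4070 nM
Compound 3, `CC1=C(C(=O)OC2CCCC2)C(c2[nH]cnc2Cl)C(C(=O)OC2CCCC2)=C(C)N1`, 97.7 nM

Of the compounds shown here, three sharing one core have been tested in an assay on isolated protein for inhibition of Voltage-dependent L-type calcium channel subunit alpha-1C (Cavia porcellus); a lower number here means a stronger inhibitor, a higher number a weaker inhibitor. Compound 1, the dipropyl diester, gives 63.1 nM. Compound 3, with two cyclopentyl esters, gives 97.7 nM, a number that sits within the usual scatter of that of compound 1, so the two cannot be told apart. Compound 2, the di-tert-butyl diester, gives 4070 nM, a number far beyond the scatter from both of the others. Among the numbers shown, compound 1 therefore stands together with compound 3 at the low end and well apart from compound 2.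

The next compound, compound 4, `CCCOC(=O)C1=C(C)NC(C)=C(C(=O)OC)C1c1[nH]cnc1Cl`, keeps one propyl ester of compound 1 and shortens the other: hydrogen in place of ethyl on a saturated chain carbon bound to an oxygen next to a carbonyl group. Among the compounds with values here, no measured pair here shows this particular change, so its effect has to be guessed from what the three values suggest: two esters of modest size, whether straight-chain or cyclic, give similar numbers, and only the bulky branched pair of compound 2 falls far behind. A methyl ester on one side is smaller still, and compound 4 is expected to stay close to compound 1, with a step from compound 1 to compound 4 of about a 1.3-fold higher number from compound 1 to compound 4 (0.10 log units; within the scatter), not clearly beyond the scatter in either direction. Compound 4 is thus estimated at 80 nM, within a range of 25 nM to 250 nM.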

Compound 4, half-maximal inhibitory concentration: 437 nM
For compound 4 the middle estimate is 5.5-fold (0.74 log units) below the measured one; the measured number lies above the stated range.
By their numbers in this assay, from the lowest: compounds 1 and 3 (each within the scatter of the next); then compound 4; then compound 2.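

In this assay, within the data shown here, the change from propyl to methyl on one ester (a 6.9-fold higher number from compound 1 to compound 4 (0.84 log units; beyond the scatter)) is the first change in this set made at a single place, and it shows that this chain cannot be shortened freely: the second propyl ester and the rest of the shared core stay as they are, yet the number rises beyond the scatter. Compounds 1, 2 and 3 each carry the same ester twice, so they could not show what one ester alone does, whereas compound 4 shows that replacing ethyl with hydrogen on this saturated chain carbon is enough by itself to weaken inhibition. No measurement shown here gives a reason for this step.

The compounds shown leave open whether an ethyl ester at this place would give a number closer to that of compound 1 or to that of compound 4, and whether a butyl ester would go further in the same direction or reverse it. They also do not tell whether a carboxylic acid or an amide could stand in place of the methoxycarbonyl group of compound 4, or what a methyl ester on both sides would give.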